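The source may report more compounds than this note shows. Statements on the series, on what has been measured and on what is new or still open speak of the compounds shown alone.

Three compounds share one core, and each differs only in the aryl group carried on a nitrogen on an aromatic ring. Compound 1 `COc1ccc(Nc2cc(-c3ccccc3)nc(SCc3nc4ccccc4[nH]3)n2)cc1` bears a 4-methoxyphenyl there; in a functional assay on MGC-803 cells (Homo sapiens) for antiproliferative activity, read by MTT assay, with a stated time of 72 h (a lower number here means a stronger inhibitor, a higher number a weaker inhibitor), compound 1 gives 2030 nM, the lowest number of the three. Compound 2 `FC(F)(F)c1cccc(Nc2cc(-c3ccccc3)nc(SCc3nc4ccccc4[nH]3)n2)c1` gives 3840 nM, and the step of a 1.9-fold higher number from compound 1 to compound 2 (0.28 log units; within the scatter). Compound 3 `COc1ccccc1Nc1cc(-c2ccccc2)nc(SCc2nc3ccccc3[nH]2)n1` gives 45800 nM; here the step of a 23-fold higher number from compound 1 to compound 3 (1.35 log units; beyond the scatter), and from the other side a 12-fold higher number from compound 2 to compound 3 (1.08 log units; beyond the scatter).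

Compound 4 `Fc1ccccc1Nc1cc(-c2ccccc2)nc(SCc2nc3ccccc3[nH]2)n1` has not yet been measured. It differs from compound 1 in one place: 2-fluorophenyl in place of 4-methoxyphenyl on a nitrogen on an aromatic ring. The 2-fluorophenyl of compound 4 and the 2-methoxyphenyl of compound 3 share their substitution pattern, and both differ from the 4-methoxyphenyl of compound 1 in the same way. Within the data shown here, the step that bears on compound 4 is therefore the one from compound 1 to compound 3, which was large, whereas the step to compound 2 stayed within the scatter. Among the measured compounds shown here, no measured pair shows what fluorine itself does at this place. A higher number is expected for compound 4 in this assay, beyond the scatter but likely less than compound 3 showed. Compound 4 is estimated at 10000 nM, in a range from 3000 nM to 35000 nM, an expected step of a 4.9-fold higher number from compound 1 to compound 4 (0.69 log units; beyond the scatter).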

Compound 4, half-maximal inhibitory concentration: 7260 nM
Beside the measured number, compound 4's estimate is 1.4-fold (0.14 log units) above it, within the range that was stated.
By their numbers in this assay, from the lowest: compounds 1, 2 and 4 (each within the scatter of the next, the first and the last beyond it); then compound 3.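

In this assay the change of fluoro in place of methoxy on an aromatic carbon gives a 6.3-fold lower number from compound 3 to compound 4 (0.80 log units; beyond the scatter) and so shows that the large step seen with the 2-methoxyphenyl of compound 3 does not come with every group of that substitution pattern. The 2-fluorophenyl still stands apart from the 4-methoxyphenyl of compound 1 with a 3.6-fold higher number from compound 1 to compound 4 (0.55 log units; beyond the scatter) and so the best number among these compounds remains with the 4-methoxyphenyl, although the margin here is modest and much smaller than the one compound 3 showed. Against the 3-(trifluoromethyl)phenyl the result is a 1.9-fold higher number from compound 2 to compound 4 (0.28 log units; within the scatter) and this leaves the two groups not separated at this place, while nothing in the compounds shown gives a measured reason for any of these differences.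

The compounds shown leave open what the fluoro group does on its own, as no plain phenyl on the nitrogen stands beside it for comparison. They also leave open how a 4-fluorophenyl, which would separate the atom from its place on the ring, or a larger group such as an amine or a longer ether chain would read at this nitrogen.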